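Swapping a Small Amine for a Ring Amine

The source may hold more compounds than are shown below. What is called first, only, known or untested is meant among the compounds shown, and "the series" means these compounds.

Of the compounds shown here, two with a shared core have so far been measured in an ADME assay on microsomes from liver (Mus musculus) for metabolic stability, read by LC-MS, tested at 1 uM; a lower number here means slower removal, a higher number faster removal of the compound. Compound 1 `CCOC(=O)C1=C(C)N/C(=C/c2cc(C)n(-c3ccc(CN(C)C)cc3)c2C)C1=O` gives 31 mL.min-1.g-1 in this assay, the lower of the two numbers. Compound 2 `CCOC(=O)C1=C(C)N/C(=C/c2cc(C)n(-c3cc(OC)c(OC)c(OO)c3)c2C)C1=O` gives 63 mL.min-1.g-1 in this assay, a higher number whose gap from compound 1 lies beyond the usual scatter of repeated measurements. Compound 3 `CCOC(=O)C1=C(C)N/C(=C/c2cc(C)n(-c3ccc(CN4CCCCC4)cc3)c2C)C1=O` has not yet been measured. It differs from compound 1 in one place: piperidin-1-yl in place of dimethylamino on a saturated chain carbon bound to an aromatic carbon. Among the compounds with values here, no measured pair shows this exact change, so there is no observed step to lean on. The step of a 1.5-fold higher number from compound 1 to compound 3 (0.16 log units; within the scatter) is expected to be modest, most likely a slight rise but possibly nothing beyond the scatter. On that basis compound 3 is expected to give about 45 mL.min-1.g-1 in this assay, within a range from 20 mL.min-1.g-1 to 100 mL.min-1.g-1.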

Compound 3, intrinsic clearance in microsomes: 60 mL.min-1.g-1
Beside the measured number, compound 3's estimate is 1.3-fold (0.12 log units) below it; the range from low to high includes it.
By their numbers in this assay, from the lowest: compounds 1, 3 and 2 (each within the scatter of the next, the first and the last beyond it).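

In this assay, putting piperidin-1-yl in place of dimethylamino on a saturated chain carbon bound to an aromatic carbon gives a 1.9-fold higher number from compound 1 to compound 3 (0.29 log units; within the scatter). This position therefore takes a group of six heavy atoms with one six-membered non-aromatic ring, instead of three heavy atoms and no ring, without a change that can be told apart from the usual spread of repeat measurements. Nothing at hand bears on what lies behind this result.

Still open, going by these compounds, is whether a ring amine with a second hetero atom, such as morpholin-4-yl, or a smaller ring amine, such as pyrrolidin-1-yl, would behave the same way at this place. A single pair also cannot show what a longer chain between the aromatic carbon and the amine would do.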